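Bromination of the core: expected tolerance in Vero cells

The source may hold more compounds than are shown below. What is called first, only, known or untested is meant among the compounds shown, and "the series" means these compounds.

Among the compounds with values here, compound 1 `COc1cc(/C(Cl)=C/C=C(\C#N)C(=O)c2c[nH]c3ccccc23)cc(OC)c1OC` is the only compound with a number in an ADME assay on Vero cells (Chlorocebus sabaeus) for cytotoxicity, read by sulforhodamine B assay, with a stated time of 48 h; a lower number here means that less compound is tolerated, a higher number that more compound is tolerated; there compound 1 gives 54200 nM. Compound 2 `COc1ccc(/C(Cl)=C/C=C(\C#N)C(=O)c2c[nH]c3ccc(Br)cc23)cc1` was assayed, and for compound 2 the entry reads "not determined" (no result reported). Compound 3 `COc1cc(/C(Cl)=C/C=C(\C#N)C(=O)c2c[nH]c3ccc(Br)cc23)cc(OC)c1OC` differs from compound 1 in one place: bromo in place of hydrogen on an aromatic carbon. Within the data shown here, no measured pair shows this change, so its effect in this assay is unknown. Compound 3 is expected to be tolerated somewhat less, with a step from a 1.5-fold lower number from compound 1 to compound 3 (0.19 log units; within the scatter) that may stay near the scatter. The estimate for compound 3 is 35000 nM, within 15000 nM to 80000 nM.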

Compound 3, concentration lethal to 50% of the cells: 41500 nM
Compound 3: middle estimate off by 1.2-fold (0.07 log units), on the low side; the measured number falls inside the stated range.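

In this assay, replacing 1H-indol-3-yl with 5-bromo-1H-indol-3-yl gives a 1.3-fold lower number from compound 1 to compound 3 (0.12 log units; within the scatter) and so this single pair does not separate bromo from hydrogen at this position. Within the data shown here, this is the first measured pair for the change, and it gives a reading at this aromatic carbon only with the substituents of compound 1. Nothing shown offers an explanation for this outcome.

On these data alone, whether an amine or a carboxylic acid at this position would also remain within the scatter of compound 1 stays open. The entry for compound 2 holds no result, so the bromo compounds cannot be compared.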